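One Ring Swap and the Expected Toxicity of Compound 3

This account rests on a few compounds, and the source may have more. Where it says the series, first, only, none or still open, it means among the compounds named here.

Measured so far:
Compound 1 `O=C(CSc1nnnn1-c1cccc2ccccc12)N/N=C/c1ccccc1Cl`: 69700 nM
Compound 2 `COc1ccc(/C=N/NC(=O)CSc2nnnn2-c2cccc3ccccc23)c(OC)c1`: 28300 nM

Both were tested in an ADME assay on MT4 cells (Homo sapiens) for cytotoxicity, read by MTT assay; on this read-out lower numbers stand for higher toxicity in this test and higher numbers for lower toxicity in this test. Among the compounds with values here, compound 2 has the lower of the two numbers; the only measured step, a 2.5-fold lower number from compound 1 to compound 2 (0.39 log units; beyond the scatter), was modest. Compound 3 `CN(C)c1ccc(/C=N/NC(=O)CSc2nnnn2-c2cccc3ccccc23)cc1` differs from compound 2 in one place: 4-(dimethylamino)phenyl in place of 2,4-dimethoxyphenyl on a carbon with a double bond to nitrogen. Within the data shown here, no measured step covers this particular exchange, and the step from compound 1 to compound 2 concerns a different pair of rings, so it offers no direct guide. The number for compound 3 is therefore expected to stay near that of compound 2, with a 1.2-fold higher number from compound 2 to compound 3 (0.09 log units; within the scatter) expected to fall within the scatter. Compound 3 is estimated at 35000 nM, ranging from 12000 nM to 100000 nM.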

Compound 3, half-maximal cytotoxic concentration: > 289000 nM
Compound 3: no number, only a limit; the forecaster's own chance of this, stated with the estimate: 15%; at least 8.2-fold (0.91 log units) between middle value and limit.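

In this assay compound 3 gives only a limit, not a number: the limit of > 289000 nM in this assay, at which 1 of the 3 values shown sits. Placing 4-(dimethylamino)phenyl on this carbon gives an at least 10-fold higher number from compound 2 to compound 3 (1.00 log units; beyond the scatter) and an at least 4.1-fold higher number from compound 1 to compound 3 (0.61 log units; beyond the scatter). The group at this position can therefore shift the read-out further than the earlier pair showed, here toward lower toxicity in this test.

The compounds shown do not separate the effect of adding the dimethylamino group from that of losing the two methoxy groups. Going by these compounds, how a plain amine or a carboxylic acid would read at this position also remains open.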